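Urea series: solubility at the para position of compound 1

This account rests on a few compounds, and the source may have more. Where it says the series, first, only, none or still open, it means among the compounds named here.

Three ureas on a shared core have been measured in a physicochemical assay for solubility, at pH 7.4; on this read-out lower numbers stand for lower solubility and higher numbers for higher solubility. Compound 1 `CSc1ccc(NC(=O)Nc2cc(C)nc3ccccc23)cc1` gives 1300 nM and stands second highest of the three. Compound 3 `COC(=O)c1cccc(NC(=O)Nc2cc(C)nc3ccccc23)c1` gives 600 nM in this assay, a lower number than compound 1 by a gap that lies beyond the scatter. Compound 2 `CSc1ccccc1NC(=O)Nc1cc(C)nc2ccccc12` gives 21000 nM in this assay, the highest number of the set and far beyond the scatter from compound 1. For the measured compounds named here, no step between two measured compounds differing in only one place is available, so nothing in the measured set directly calibrates the change examined next.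

Compound 4 `Cc1cc(NC(=O)Nc2ccc(OC(F)(F)F)cc2)c2ccccc2n1` is not yet measured in this assay. It differs from compound 1 as follows: trifluoromethoxy in place of methylsulfanyl on an aromatic carbon. The change replaces one group with another of the same acceptor count at the same place, para to a large group on the six-membered aromatic ring of carbon only.

Going by the values given here, with no matching measured step to rest on, the expectation for the step from compound 1 to compound 4 is a small one, a 1.3-fold lower number from compound 1 to compound 4 (0.11 log units; within the scatter), not clearly beyond the scatter in either direction. For compound 4 the estimated value in this assay is 1000 nM, with an expected range from 300 nM to 4000 nM.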

Compound 4, solubility: 300 nM
Beside the measured number, compound 4's estimate is 3.3-fold (0.52 log units) above it; the measured number falls inside the stated range.
By their numbers in this assay, from the lowest: compounds 4 and 3 (each within the scatter of the next); then compound 1; then compound 2.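

Within this assay, the series now has its first step between two compounds differing in one place: trifluoromethoxy in place of methylsulfanyl, on an aromatic carbon para to a large group, gives a 4.3-fold lower number from compound 1 to compound 4 (0.64 log units; beyond the scatter), a modest move beyond the scatter. The earlier compounds shown here offered no calibration for any change here, and this step shows that the number at this position can move beyond the scatter on exchanging one group for another with the same hydrogen-bond acceptor count, neither carrying a net charge and neither adding a ring. Nothing available explains this step, and the contribution of the larger heavy-atom count of trifluoromethoxy, 5 against 2, cannot be separated from that of the change in atoms.

One step cannot show how the number at this position would respond to other groups, such as an amine, a carboxylic acid or a longer chain. Also open, from the compounds shown here alone, is whether the same exchange on compound 2 at 21000 nM would move the number in the same direction and by a similar size.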